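Hydroxy to ((chloromethyl)carbonyl)amino: cytotoxicity notes

The compounds below may be only part of what the source reports. "The series", "measured", "known", "first", "only" and "open" are said of these compounds alone.

Among the measured compounds shown here, in an ADME assay on MDBK cells (Bos taurus) for cytotoxicity, read by MTT assay, with a stated time of 96 h (on this read-out higher numbers stand for lower toxicity in this test and lower numbers for higher toxicity in this test), compound 1 `Oc1ccc(-c2nc3cc(C(F)(F)F)ccc3[nH]2)cc1` gives 51000 nM, the only number among the three measured compounds. Compound 2 `COc1ccc(-c2nc3cc(C(C)=O)ccc3[nH]2)c(OC)c1` sits at the limit of this assay, > 100000 nM. Compound 3 `CCC(=O)Nc1ccc(-c2nc3ccccc3[nH]2)cc1` likewise sits at the limit, > 100000 nM. Compound 1 therefore stands at the more toxic end of what is known so far, the other two being at the limit of > 100000 nM in this assay, at which 2 of the 3 values shown sit. Compound 4 `O=C(CCl)Nc1ccc(-c2nc3cc(C(F)(F)F)ccc3[nH]2)cc1` differs from compound 1 by ((chloromethyl)carbonyl)amino in place of hydroxy on an aromatic carbon. For the measured compounds named here, no measured pair in this set shows that change, so the expectation rests on compound 1 alone. The step of a 1.7-fold lower number from compound 1 to compound 4 (0.23 log units; within the scatter) is expected to be small, toward higher toxicity, and close to the usual scatter. Compound 4 is expected at 30000 nM, with a range from 8000 nM to 100000 nM.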

Compound 4, half-maximal cytotoxic concentration: 17000 nM
Estimate against measurement, compound 4: 1.8-fold (0.25 log units) above; measured number inside the range.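

In this assay, this position, on an aromatic carbon para to a large group, now has its first readable step: ((chloromethyl)carbonyl)amino in place of hydroxy gives a 3.0-fold lower number from compound 1 to compound 4 (0.48 log units; beyond the scatter). The step is modest but beyond the scatter, so this position is not silent in this test. Only compound 1 and compound 4 give numbers, and the rest stand at a limit: the limit of > 100000 nM in this assay, at which 2 of the 4 values shown sit.

This single pair leaves open whether the chlorine or the amide carries the step. An acetylamino group or a free amine at the same position would separate the two.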